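Trifluoromethyl for nitro on a benzyl ether

The source may hold more compounds than are shown below. What is called first, only, known or untested is meant among the compounds shown, and "the series" means these compounds.

Measured compounds:
- compound 1, `CC(=O)c1ccc(OCc2cccc([N+](=O)[O-])c2)cc1`: 104 nM
- compound 2, `CC(=O)c1ccc(OCc2cc(F)c(F)c(F)c2)cc1`: 84.1 nM

Of the compounds shown here, two sharing one core have been measured in an assay on isolated protein for inhibition of Amine oxidase [flavin-containing] B (Homo sapiens), read by Amplex Red, with a stated time of 15 min; on this read-out higher numbers stand for weaker inhibition and lower numbers for stronger inhibition. Compound 1 gives 104 nM, the higher of the two numbers; compound 2 gives 84.1 nM, which lies within the scatter of compound 1, so the two cannot be told apart on this read-out.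

Compound 3, `CC(=O)c1ccc(OCc2cccc(C(F)(F)F)c2)cc1`, has not yet been measured in this assay. Its change from compound 1 is trifluoromethyl in place of nitro on an aromatic carbon, the place being meta to a large group. Among the compounds with values here, no measured pair shows this exchange, so the size of the step is uncertain. Since compound 2, bearing only fluorine on that ring, gives 84.1 nM, a small step toward a lower number is expected, likely not beyond the scatter.

Compound 3 is thus estimated at 70 nM, between 25 nM and 200 nM, which would be a step of a 1.5-fold lower number from compound 1 to compound 3 (0.17 log units; within the scatter) expected from compound 1.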

Compound 3, half-maximal inhibitory concentration: 58.2 nM
Compound 3: middle estimate off by 1.2-fold (0.08 log units), on the high side; the measured number falls inside the stated range.
By their numbers in this assay, from the lowest: compounds 3, 2 and 1 (each within the scatter of the next).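

Placing trifluoromethyl where compound 1 carries nitro, on an aromatic carbon meta to a large group, gives a 1.8-fold lower number from compound 1 to compound 3 (0.25 log units; within the scatter) in this assay, and this is the only single-place comparison among the compounds shown. It shows that at this place, nitro, with its hydrogen-bond acceptors, and trifluoromethyl, which has none, cannot be told apart on this read-out. No measurement shown here explains the size of this step.

Going by these compounds, whether an amine, a carboxylic acid or a nitrile on the same aromatic carbon would also stay within the scatter of compound 1 remains open. Also open, on these data alone, is whether trifluoromethyl would give a similar number on another carbon of this ring, or with a longer chain in place of the ether link.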